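Adding bromo to compound 2 in an aminopeptidase inhibition screen

A few compounds are considered here, and "the series" means these few. Any claim that something is new, unique, unknown or untested is made for them only; others in the source may bear on it.

Measured so far:
compound 1, `O=C(NC1(C(=O)O)CCCCC1)c1cccc2c(Br)c(-c3ccc(Cl)cc3)oc12`: 4.37%
compound 2, `CC(C)(NC(=O)c1cccc2cc(-c3ccc(Cl)cc3)oc12)C(=O)O`: 25.2%

Two compounds share a fused core carrying a 4-chlorophenyl group and an amide linked to an amino acid. In an assay on isolated protein for inhibition of endoplasmic reticulum aminopeptidase 1 (Homo sapiens), read by mass spectrometry, with stated times of 15 min and 25 min, tested at 10 uM (on this read-out lower numbers stand for less inhibition and higher numbers for more inhibition at the one concentration tested (going by the name of the read-out)), compound 2 gives 25.2%, the higher of the two numbers; compound 1 gives 4.37%, a gap beyond the usual scatter. The two differ in more than one place, so the numbers alone say nothing about what the bromo contributes. Compound 3, `CC(C)(NC(=O)c1cccc2c(Br)c(-c3ccc(Cl)cc3)oc12)C(=O)O`, makes that question testable: bromo in place of hydrogen on an aromatic carbon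

Within the data shown here, because compound 1, the only bromo-bearing compound, gives 4.37%, a downward step of modest size is expected, though the second structural difference leaves this uncertain. The step of a number 10.2 percentage points lower from compound 2 to compound 3 (beyond the scatter) is expected. Compound 3 is thus estimated at 15%, within a range from 2% to 32%.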

Compound 3, a percentage reported as inhibition, at one concentration (the size of the read-out at that concentration, not a potency): > 30%
Compound 3 gave a limit, no number; the forecaster's own chance of this, stated with the estimate: 3%; at least 15 percentage points between middle value and limit.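

Compound 3 reaches a limit of this assay rather than a number: the limit of > 30% in this assay, at which 1 of the 3 values shown sits.

Bromo in place of hydrogen on this aromatic carbon of the five-membered ring shows no loss of inhibition (a number at least 4.8 percentage points higher from compound 2 to compound 3 (that floor lies within the scatter)), although that floor alone does not establish a gain. With bromo present in both compounds, 1-carboxy-1-methylethyl in place of 1-carboxycyclohexyl on the amide-type nitrogen gives a clear difference (a number at least 25.6 percentage points higher from compound 1 to compound 3 (beyond the scatter)), so the low value of compound 1 goes with its 1-carboxycyclohexyl group and not with the bromo.

On these data alone, how far the inhibition by compound 3 extends past the limit remains open. So does whether a methyl group or an amine on the same aromatic carbon would keep the inhibition seen with bromo.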